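A few compounds are considered here, and "the series" means these few. Any claim that something is new, unique, unknown or untested is made for them only; others in the source may bear on it.

Measured in an assay on isolated protein for inhibition of interferon-induced, double-stranded RNA-activated protein kinase (Homo sapiens), read by luminescence, with a stated time of 10 min; a higher number here means a weaker inhibitor, a lower number a stronger inhibitor:

Compound 1 `Cc1[nH]c2ccccc2c1-c1ccnc(NCCO)n1`: 11000 nM
Compound 2 `OCCNc1nccc(-c2c[nH]c3ccccc23)n1`: 11000 nM
Compound 3 `Cc1[nH]c2ccccc2c1-c1ccnc(N2CCN(c3ccc(F)cc3)CC2)n1`: only a limit of the assay, > 100000 nM

Among the compounds with values here, compound 2 stands level with compound 1 on this assay, with no change at the digits printed from compound 1 to compound 2 (within the scatter), the one measured step. Compound 4 `COC(=O)c1ccc2c(-c3ccnc(NCCO)n3)c[nH]c2c1` differs from compound 2 by methoxycarbonyl in place of hydrogen on an aromatic carbon. Within the data shown here, no measured step touches this change: the only step that was measured swapped a methyl for a hydrogen at another place and moved nothing beyond the scatter, so it gives no direction for adding a methoxycarbonyl. With nothing pointing up or down, the expectation is a step of no size beyond the scatter. Compound 4 is therefore expected to give about 11000 nM, within 3000 nM to 40000 nM, a step of no change at the digits printed from compound 2 to compound 4 (within the scatter) from compound 2.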

Compound 4, half-maximal inhibitory concentration: 9000 nM
Compound 4: middle estimate off by 1.2-fold (0.09 log units), on the high side, within the range that was stated.
By their numbers in this assay, from the lowest: compounds 4, 1 and 2 (each within the scatter of the next). At a limit, above all of these: compound 3.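

In this assay, methoxycarbonyl in place of hydrogen on this aromatic carbon gives a 1.2-fold lower number from compound 2 to compound 4 (0.09 log units; within the scatter), so the value stays within the scatter. Within the data shown here, this shows that the position, which carries hydrogen in the earlier compounds, can take a group of 4 heavy atoms without a change beyond the scatter. Nothing shown accounts for this result.

On these data alone, whether a carboxylic acid or an amine at this position would move the number beyond the scatter remains open. So does the effect of methoxycarbonyl on the other carbons of this ring.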